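Bromo for hydrogen on the pendant phenyl

This account rests on a few compounds, and the source may have more. Where it says the series, first, only, none or still open, it means among the compounds named here.

Compound 3 `Cc1cc(O)c(C(=O)/C=C/c2ccc(Br)cc2)c(-c2ccccc2)c1C(=O)/C=C/c1ccc(Br)cc1` gives 10000 nM in a functional assay on MDA-MB-231 cells (Homo sapiens) for cytotoxicity, read by MTT assay, with a stated time of 24 h (a lower number here means a stronger inhibitor, a higher number a weaker inhibitor), and sits second highest of the three numbers. Compound 1 `Cc1cc(O)c(C(=O)/C=C/c2ccccc2)c(-c2ccccc2)c1C(=O)/C=C/c1ccccc1` gives 8500 nM, a gap within the scatter; compound 2 `Cc1cc(O)c(C(=O)/C=C/c2ccc(Br)cc2)c(-c2ccc(OCc3ccccc3)cc2)c1C(=O)/C=C/c1ccc(Br)cc1` gives 30000 nM. Among the measured compounds shown here, the one single-point step recorded, a 3.0-fold lower number from compound 2 to compound 3 (0.48 log units; beyond the scatter), removes a benzyloxy from the pendant phenyl. Compound 4 `Cc1cc(O)c(C(=O)/C=C/c2ccc(Br)cc2)c(-c2ccc(Br)cc2)c1C(=O)/C=C/c1ccc(Br)cc1` carries bromo in place of hydrogen on an aromatic carbon, so a bromo arrives where benzyloxy was lost, a substituent far smaller than benzyloxy. That step is the only one bearing here; it points towards a higher number when the pendant phenyl is substituted, but bromo is not benzyloxy, so the expected step of a 1.3-fold higher number from compound 3 to compound 4 (0.11 log units; within the scatter) is small, likely within the scatter. Compound 4 is estimated at 13000 nM, in the range 5000 nM to 35000 nM.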

Compound 4, half-maximal inhibitory concentration: 18000 nM
For compound 4 the middle estimate is 1.4-fold (0.14 log units) below the measured one; low and high end bracket the measured number.
By their numbers in this assay, from the lowest: compounds 1, 3, 4 and 2 (each within the scatter of the next, the first and the last beyond it).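

In this assay, bromo in place of hydrogen at this position of the pendant phenyl, para to a large group, gives a 1.8-fold higher number from compound 3 to compound 4 (0.26 log units; within the scatter), and bromo in place of benzyloxy gives a 1.7-fold lower number from compound 2 to compound 4 (0.22 log units; within the scatter). Compound 4 therefore cannot be separated from either neighbour, although a 3.0-fold lower number from compound 2 to compound 3 (0.48 log units; beyond the scatter) does separate those two. No measurement on hand bears on the reason for these steps. Open, as far as these compounds go, is whether an amine or a carboxylic acid at this position would give a step beyond the scatter, and whether bromo here would read the same with the unsubstituted styryl arms of compound 1.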